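Aryloxyquinoline dienones: methoxy additions at the assay limit

The compounds below may be only part of what the source reports. "The series", "measured", "known", "first", "only" and "open" are said of these compounds alone.

Three members of the series, all on the shared core, are measured in a functional assay on NCI-H460 cells (Homo sapiens) for cytotoxicity, read by MTT assay, with a stated time of 48 h; a higher number here means a weaker inhibitor, a lower number a stronger inhibitor. Compound 1 `COc1ccc(/C=C/C(=O)/C=C/c2cc3ccccc3nc2Oc2ccccc2)cc1` gives in this assay a value of > 10000 nM, which is a limit of the assay and not a number. Compound 2 `COc1ccc(/C=C/C(=O)/C=C/c2cc3ccccc3nc2Oc2ccccc2)cc1OC` carries the change (methoxy in place of hydrogen on an aromatic carbon). In this assay compound 2 gives > 10000 nM, again only a limit. The step that the two limits leave unreadable from compound 1 to compound 2 thus has no readable size. Compound 3 `COc1ccc(/C=C/C(=O)/C=C/c2cc3ccccc3nc2Oc2cccc(Cl)c2)cc1OC` carries a chloro; in this assay compound 3 gives > 10000 nM, also a limit, and a step that the two limits leave unreadable from compound 2 to compound 3 is likewise unreadable. The difference between the cores of compound 1 and compound 3 is not broken down here. Compound 4 `COc1cc(OC)c(OC)cc1/C=C/C(=O)/C=C/c1cc2ccccc2nc1Oc1cccc(Cl)c1`, not yet measured, differs from compound 3 by methoxy in place of hydrogen on an aromatic carbon: the same kind of change as from compound 1 to compound 2, but the entering methoxy now sits ortho to a large group, meta to a methoxy group and para to a methoxy group, where before it sat ortho to a methoxy group and meta to a large group. Because (the limit of > 10000 nM in this assay, at which 3 of the 3 values shown sit), the earlier step gives no size, so the expected step that the limit leaves unreadable from compound 3 to compound 4 rests only on the three limits. Compound 4 is expected at 20000 nM, between 7000 nM and 60000 nM.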

Compound 4, half-maximal inhibitory concentration: > 10000 nM
Compound 4 was reported as a limit; the forecaster's own chance of this, stated with the estimate: 80%; the middle value lies beyond the limit too.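

No step from compound 3 to compound 4 can be read, since both values are limits and not numbers: the limit of > 10000 nM in this assay, at which 4 of the 4 values shown sit.

Still open, from the compounds shown here alone, is whether any change on the shared core gives a readable value, and how large the methoxy and chloro steps are.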